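Diethylamino to propylamino on the side chain

The source may hold more compounds than are shown below. What is called first, only, known or untested is meant among the compounds shown, and "the series" means these compounds.

Within the data shown here, in a functional assay on MCF7 cells (Homo sapiens) for antiproliferative activity (on this read-out higher numbers stand for weaker inhibition and lower numbers for stronger inhibition), compound 2 (`CCN(CC)CCCOc1ccc2cc(NC(=O)c3ccc(O)c(CC=C(C)C)c3)c(=O)oc2c1C`) gives 6390 nM, the higher of the two numbers so far, while compound 1 (`CC(C)=CCc1cc(C(=O)Nc2cc3ccc(OCC4CCCNC4)c(C)c3oc2=O)ccc1O`) gives 790 nM. Compound 3 (`CCCNCCCOc1ccc2cc(NC(=O)c3ccc(O)c(CC=C(C)C)c3)c(=O)oc2c1C`) carries propylamino in place of diethylamino on a saturated chain carbon, three bonds along the chain from an oxygen on an aromatic ring. Among the measured compounds shown here, only one measured step bears on this change: an 8.1-fold higher number from compound 1 to compound 2 (0.91 log units; beyond the scatter), modest but beyond the scatter, with 2-(diethylamino)ethyl in place of piperidin-3-yl. Since that step involves a different group, only part of it is expected to carry over, towards a lower number. The expected change is a 2.3-fold lower number from compound 2 to compound 3 (0.36 log units; beyond the scatter). The estimate for compound 3 is 2800 nM, within 900 nM to 8000 nM.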

Compound 3, half-maximal inhibitory concentration: 980 nM
The estimate for compound 3 lay 2.9-fold (0.46 log units) above the measured number; the measured number falls inside the stated range.
By their numbers in this assay, from the lowest: compounds 1 and 3 (each within the scatter of the next); then compound 2.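

In this assay, the step at this position, a 6.5-fold lower number from compound 2 to compound 3 (0.81 log units; beyond the scatter), shows that the amine on the same chain alone moves the number beyond the scatter, with the change from diethylamino to propylamino adding a hydrogen-bond donor and removing a carbon. The open-chain 2-(propylamino)ethyl group also stands level with piperidin-3-yl, a 1.2-fold higher number from compound 1 to compound 3 (0.09 log units; within the scatter), so a ring is not needed to reach that range among these compounds. No measurement at hand explains the step.

On these data alone, whether the added donor or the lost carbon carries the step remains open. A butylamino group on the same chain would bear on that.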